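Pyridyl isomer step on the shared amide core

The compounds below may be only part of what the source reports. "The series", "measured", "known", "first", "only" and "open" are said of these compounds alone.

Compound 1, `CNC(=O)N1CCCc2ccc(NC(=O)c3ccc(-c4ccn(C)n4)cc3)cc21`, gives 97% in a functional assay on MV4-11 cells (Homo sapiens) for antiproliferative activity, with a stated time of 6 days, tested at 6.25 uM; on this read-out higher numbers stand for a stronger effect at the one concentration tested and lower numbers for a weaker effect.
Compound 2, `CNC(=O)N1CCCc2ccc(NC(=O)c3ccc(-c4ccncc4)cc3)cc21`, gives 88.7% in this assay.

On the numbers shown compound 2 sits alongside compound 1, the only other measured compound: a number 8.3 percentage points lower from compound 1 to compound 2 (within the scatter). Compound 3, `CNC(=O)N1CCCc2ccc(NC(=O)c3ccc(-c4cccnc4)cc3)cc21`, is not yet measured; it differs from compound 2 by pyridin-3-yl in place of pyridin-4-yl on an aromatic carbon. Among the measured compounds shown here, the one measured step concerns the same aromatic carbon, where exchanging the attached aromatic ring left the number within the scatter. No step beyond the scatter is therefore expected in this assay. Compound 3 is estimated at 86%, between 68% and 98%, an expected step of a number 2.7 percentage points lower from compound 2 to compound 3 (within the scatter).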

Compound 3, a percentage reported as inhibition, at one concentration (the size of the read-out at that concentration, not a potency): 92.1%
Beside the measured number, compound 3's estimate is 6.1 percentage points below it; measured number inside the range.
By their numbers in this assay, from the lowest: compounds 2, 3 and 1 (each within the scatter of the next).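

In this assay, the isomer exchange gives a number 3.4 percentage points higher from compound 2 to compound 3 (within the scatter), so on this aromatic carbon the place of the nitrogen within the pyridine ring does not separate the compounds. The exchange of ring type gives a number 4.9 percentage points lower from compound 1 to compound 3 (within the scatter), so pyridin-3-yl joins pyridin-4-yl in staying within the scatter of 1-methyl-1H-pyrazol-3-yl. No measured evidence accounts for these numbers.

All three groups here are aromatic rings, read at one concentration, so any potency differences among them remain unresolved. From the compounds shown here alone, whether pyridin-2-yl, a morpholine, an amine or a carboxylic acid on this carbon would keep the number remains open.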